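From propyl to isopropyl on a sulfur

This account rests on a few compounds, and the source may have more. Where it says the series, first, only, none or still open, it means among the compounds named here.

Measured so far in a functional assay on HCT-116 cells (Homo sapiens) for cytotoxicity, read by MTT assay, with a stated time of 72 h; a higher number here means a weaker inhibitor, a lower number a stronger inhibitor

Compound 1 `S=C=NCCCCSCc1ccccc1` gives 41500 nM
Compound 2 `CCC[S+]([O-])CCCCN=C=S` gives 3950 nM

Of these two compounds, compound 2 has the lower number and so is the stronger inhibitor. The gap up to compound 1 lies beyond the usual scatter of repeated measurements. Next comes compound 3 (`CC(C)[S+]([O-])CCCCN=C=S`), which has the same atoms as compound 2, joined differently (isopropyl in place of propyl on a sulfur). It carries isopropyl in place of propyl on a sulfur whose other neighbours are oxygen and a saturated chain carbon.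

Among the compounds with values here, no two measured compounds differ in one place only, so no measured step speaks directly to this swap. The expectation therefore starts from compound 2 at 3950 nM and rests on how small the structural change is. In this assay no step beyond the scatter is expected, in either direction. The estimate is a 1.1-fold higher number from compound 2 to compound 3 (0.03 log units; within the scatter) and this is expected to stay within that scatter. For compound 3 the expected value is 4200 nM with an estimated range of 2000 nM to 9000 nM around it.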

Compound 3, half-maximal inhibitory concentration: 3740 nM
The estimate for compound 3 lay 1.1-fold (0.05 log units) above the measured number; the measured number falls inside the stated range.
By their numbers in this assay, from the lowest: compounds 3 and 2 (each within the scatter of the next); then compound 1.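

Within the data shown here, this is the first measured step that changes only one place, and in this assay it reads a 1.1-fold lower number from compound 2 to compound 3 (0.02 log units; within the scatter) and stays within the usual scatter of repeated measurements. On a sulfur whose other neighbours are oxygen and a saturated chain carbon, propyl and isopropyl therefore cannot be told apart in this read-out, even though the same three carbons are joined differently. Nothing measured on these compounds offers an explanation for this match.

Open, going by these compounds, is whether a larger or differently shaped group on this sulfur, such as tert-butyl, cyclopropyl or a longer chain like hexyl, would stay equally close to compound 2 and compound 3. Also open, on these data alone, is what a sulfide or a sulfone in place of the sulfoxide would give with the propyl or isopropyl group, a question compound 1 cannot answer, as it differs from compound 2 and compound 3 in more than one place.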